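The source may hold more compounds than are shown below. What is called first, only, known or untested is meant among the compounds shown, and "the series" means these compounds.

Working notes on the series. The shared core carries a side chain that ends in an amine nitrogen, and the group on that nitrogen is the point of variation. Compound 1 `COc1ccc(NC[C@@H](O)COc2ccc(N3C[C@H](CNC(C)=O)OC3=O)cc2F)cc1` bears a 4-methoxyphenyl there; in a physicochemical assay for solubility, read by HPLC (a higher number here means a more soluble compound, a lower number a less soluble compound), compound 1 gives 1300 nM, the lowest of the three numbers measured. Compound 3 `CC(=O)NC[C@H]1CN(c2ccc(OC[C@H](O)CNC3CC3)c(F)c2)C(=O)O1` carries a cyclopropyl on the same nitrogen, and in this assay compound 3 gives 2200000 nM; the step is a 1700-fold higher number from compound 1 to compound 3 (3.23 log units; beyond the scatter). Compound 2 `CC(=O)NC[C@H]1CN(c2ccc(OC[C@@H](O)CNc3cccnc3)c(F)c2)C(=O)O1` has a pyridin-3-yl on that nitrogen, and in this assay compound 2 gives 3040000 nM, a step of a 1.4-fold lower number from compound 2 to compound 3 (0.14 log units; within the scatter) on the way to compound 3, so compound 2 and compound 3 sit together and far from compound 1.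

Compound 4 `CC(=O)NC[C@H]1CN(c2ccc(OC[C@H](O)CNCCC(C)C)c(F)c2)C(=O)O1` is not yet measured. Relative to compound 1 the change is isopentyl in place of 4-methoxyphenyl on an amine nitrogen. Within the data shown here, the step that bears on it is the one from compound 1 to compound 3, where an aromatic group on the amine nitrogen gave way to a ring-free saturated group and the number rose by a 1700-fold higher number from compound 1 to compound 3 (3.23 log units; beyond the scatter). Among the measured compounds shown here, the same kind of exchange is made here, so a large rise in this assay is expected, though the single comparable step does not fix its exact size. For compound 4 the estimated step is a 620-fold higher number from compound 1 to compound 4 (2.79 log units; beyond the scatter). The expected value for compound 4 in this assay is 800000 nM, within a range from 150000 nM to 3000000 nM.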

Compound 4, solubility: 7280000 nM
Compound 4: the middle estimate sits 9.1-fold (0.96 log units) below what was measured, outside the stated range (above it).
By their numbers in this assay, from the lowest: compound 1; then compounds 3 and 2 (each within the scatter of the next); then compound 4.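

In this assay, a second ring-free saturated group on the amine nitrogen lands far above the 4-methoxyphenyl (a 5600-fold higher number from compound 1 to compound 4 (3.75 log units; beyond the scatter)), so the large step is not particular to cyclopropyl. The saturated groups are not interchangeable at this position: isopentyl in place of cyclopropyl gives a modest step beyond the scatter (a 3.3-fold higher number from compound 3 to compound 4 (0.52 log units; beyond the scatter)), and compound 4 also stands clear of the pyridin-3-yl compound (a 2.4-fold higher number from compound 2 to compound 4 (0.38 log units; beyond the scatter)), although compound 2 and compound 3 lie within the scatter of each other. Compound 2 still goes against any reading that an aromatic ring on this nitrogen brings the number down, since only compound 1 sits far below the others, and nothing shown accounts for these steps.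

The compounds shown leave open whether the low number of compound 1 goes with its methoxy group or with its carbon-only aromatic ring, which a plain phenyl on the same nitrogen would separate. They also leave open whether the number keeps rising from cyclopropyl to isopentyl to a longer chain such as n-octyl, or falls away again.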